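Dimethylamino on the Benzylidene Arm of a Thiosemicarbazone

The source may report more compounds than this note shows. Statements on the series, on what has been measured and on what is new or still open speak of the compounds shown alone.

Compound 1 `CC1=CC[C@H](C(C)(C)N=C=S)CC1`: > 100000 nM
Compound 2 `CC1=CC[C@H](C(C)(C)NC(=S)N/N=C/c2ccccc2)CC1`: 5700 nM

In a functional assay on PC-3 cells (Homo sapiens) for inhibition, read by sulforhodamine B assay, with a stated time of 48 h (on this read-out lower numbers stand for stronger inhibition of growth and higher numbers for weaker inhibition of growth), compound 1 gives > 100000 nM, which is a limit of the assay and not a number. Compound 2 gives 5700 nM, the only number shown. The other value shown is the limit of > 100000 nM in this assay, at which 1 of the 2 values shown sits. Compound 3 `CC1=CC[C@H](C(C)(C)NC(=S)N/N=C/c2ccc(N(C)C)cc2)CC1` carries dimethylamino in place of hydrogen on an aromatic carbon. Among the measured compounds shown here, no measured pair separates by this change, so its size is unknown; a step within the usual scatter, or a modest gain, is expected. For compound 3 the estimate is 4500 nM, ranging from 1200 nM to 15000 nM. The expected step is a 1.3-fold lower number from compound 2 to compound 3 (0.10 log units; within the scatter).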

Compound 3, concentration for total growth inhibition: < 700 nM
Compound 3 ended at the assay's limit (the forecaster's own chance of this, stated with the estimate: 5%); middle value at least 6.4-fold (0.80 log units) away from the limit.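

The aromatic ring of compound 2 can carry a group at this place, para to a large group, without loss of growth inhibition: dimethylamino in place of hydrogen gives an at least 8.1-fold lower number from compound 2 to compound 3 (0.91 log units; beyond the scatter) in this assay. On these data alone, compound 3 gives < 700 nM, which is a limit of the assay and not a number, so the full size of the step remains unknown. The compounds shown leave open whether a plain amine or a methoxy group at this place would do the same. They also leave open how dimethylamino would behave elsewhere on the ring.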